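The source may hold more compounds than are shown below. What is called first, only, known or untested is meant among the compounds shown, and "the series" means these compounds.

Measured compounds:
- compound 1, `CCCCN(C)Cc1c(C(F)(F)F)nc2n(-c3c(C)cc(C)cc3C)c(Cl)cn12`, in an assay on cells for displacement of a labelled ligand from corticotropin-releasing factor receptor 1 (Homo sapiens), with a stated time of 100 min (a higher number here means a weaker inhibitor, a lower number a stronger inhibitor), gives 310 nM
- compound 2, `C=CCN(CCC)Cc1c(C(F)(F)F)nc2n(-c3c(C)cc(C)cc3C)c(Cl)cn12`, in this assay gives 4.5 nM

Going by the values given here, compound 2 has the lowest of the two numbers in this assay, and the only other measured compound, compound 1, sits a 69-fold lower number from compound 1 to compound 2 (1.84 log units; beyond the scatter) away from it. That single step is the one point of reference for what follows, and it shows that exchanging the two groups on the amine nitrogen can move the number a great deal.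

Compound 3, `CCN(CCC1CC1)Cc1c(C(F)(F)F)nc2n(-c3c(C)cc(C)cc3C)c(Cl)cn12`, has not yet been measured. It differs from compound 2 in one place: (2-cyclopropylethyl)(ethyl)amino in place of allyl(propyl)amino on a saturated chain carbon bound to an aromatic carbon. The amine nitrogen again keeps two saturated chain groups, but the pair is different from both compound 1 and compound 2, so the earlier step does not say in which direction this change will run. Because compound 2 is already strong at 4.5 nM, a move of only moderate size seems the most reasonable expectation, with more room to climb than to fall. The number for compound 3 is therefore estimated at 9 nM, within 2.5 nM to 40 nM. This estimate means a step of a 2.0-fold higher number from compound 2 to compound 3 (0.30 log units; within the scatter).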

Compound 3, inhibition constant: 13 nM
For compound 3 the middle estimate is 1.4-fold (0.16 log units) below the measured one, within the range that was stated.
By their numbers in this assay, from the lowest: compound 2; then compound 3; then compound 1.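

In this assay, the amine at this position accepts a quite different pair of groups at modest cost: replacing allyl(propyl)amino with (2-cyclopropylethyl)(ethyl)amino removes the double bond, adds a three-membered ring of carbon only and gives a 2.9-fold higher number from compound 2 to compound 3 (0.46 log units; beyond the scatter) in the measured number. The same new group still compares well with butyl(methyl)amino, with a 24-fold lower number from compound 1 to compound 3 (1.38 log units; beyond the scatter), so the large gain seen earlier is not unique to the allyl(propyl)amino group. A double bond is therefore not required for a low number here, since compound 3 has none outside its aromatic rings, and a ring is not required either, since compound 2 has none, although compound 1 lacks both and has the highest number of the three.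

No measurement shown explains why these groups move the number as they do. From the compounds shown here alone, with each amine differing in both of its groups, the effect of each group cannot be separated, and it remains open whether a plain dipropylamino group, with neither a double bond nor a ring, would stay close to compound 2 or fall back towards compound 1.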